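A few compounds are considered here, and "the series" means these few. Any claim that something is new, unique, unknown or untested is made for them only; others in the source may bear on it.

Compound 1 `CCN(C)c1nc(Cc2c(F)cccc2F)c(C)c(=O)[nH]1`: > 85000 nM, a limit.
Compound 2 `Cc1c(Cc2c(F)cccc2F)nc(N2CCCCCC2)[nH]c1=O`: > 75000 nM, a limit.
Compound 3 `CCN(C)c1nc(C(C)c2c(F)cccc2F)c(C)c(=O)[nH]1`: 81000 nM.

All three were tested in an ADME assay on MT4 cells (Homo sapiens) for cytotoxicity, read by MTT assay, with a stated time of 4 days; on this read-out lower numbers stand for higher toxicity in this test and higher numbers for lower toxicity in this test. Going by the values given here, compound 3 holds the only actual number, as the other two results are limits. Compound 4 `Cc1c(C(C)c2c(F)cccc2F)nc(N2CCCCC2)[nH]c1=O` keeps the core of compound 3 but exchanges one group: piperidin-1-yl in place of ethyl(methyl)amino on an aromatic carbon. The nearest parallel is a step that the two limits leave unreadable from compound 1 to compound 2, which also replaces ethyl(methyl)amino but gives no readable size. The other measured change, at a different place, is an at least 1.0-fold lower number from compound 1 to compound 3 (0.02 log units; that floor lies within the scatter). With no sized evidence for a shift, no change beyond the scatter is expected in this assay. The expected change is a 1.2-fold lower number from compound 3 to compound 4 (0.06 log units; within the scatter). For compound 4 the estimated value is 70000 nM, with an expected range from 35000 nM to 130000 nM.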

Compound 4, half-maximal cytotoxic concentration: > 75000 nM
Compound 4: only a limit was reported; the forecaster's own chance of this, stated with the estimate: 50%; middle value at least 1.0-fold (0.02 log units) away from the limit.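

Going by these compounds alone, compound 4 gives only a limit in this assay, so no step from compound 3 to compound 4 can be read. The compounds shown leave open whether piperidin-1-yl in place of ethyl(methyl)amino shifts this result at all.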